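Swapping a Thiophene for Chlorophenyl on the Enone Core

The compounds below may be only part of what the source reports. "The series", "measured", "known", "first", "only" and "open" are said of these compounds alone.

Among the measured compounds shown here, compound 2 `Cc1ccsc1/C=C(/SCc1ccc(Cl)cc1)C(=O)c1ccc(Br)cc1` gives 25000 nM in a functional assay on DU-145 cells (Homo sapiens) for inhibition, read by trypan blue exclusion, with a stated time of 96 h (a higher number here means a weaker inhibitor of growth, a lower number a stronger inhibitor of growth), the highest of the two numbers known so far; compound 1 `O=C(/C(=C\c1ccc(Cl)cc1)Sc1ccc(Br)cc1)c1ccc(Br)cc1` gives 1000 nM in this assay. Compound 3 `O=C(/C(=C\c1ccc(Cl)cc1)SCc1ccc(Cl)cc1)c1ccc(Br)cc1` differs from compound 2 by 4-chlorophenyl in place of 3-methylthiophen-2-yl on a double-bonded chain carbon bound to a double-bonded chain carbon. For the measured compounds named here, no measured pair shows this exact change. Compound 1 carries the same 4-chlorophenyl and gives 1000 nM, so a sizeable step to a lower number is expected from compound 2 to compound 3, an 8.3-fold lower number from compound 2 to compound 3 (0.92 log units; beyond the scatter). Compound 3 is therefore estimated at 3000 nM, with a likely range from 800 nM to 12000 nM.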

Compound 3, concentration for 50% growth inhibition: 10000 nM
For compound 3 the middle estimate is 3.3-fold (0.52 log units) below the measured one, and the stated range covers the measured number.
By their numbers in this assay, from the lowest: compound 1; then compound 3; then compound 2.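

In this assay, 4-chlorophenyl in place of 3-methylthiophen-2-yl gives a 2.5-fold lower number from compound 2 to compound 3 (0.40 log units; beyond the scatter) and so shows that this chain carbon responds to the ring it carries, though modestly. On the sulfur, 4-chlorobenzyl in place of 4-bromophenyl gives a 10-fold higher number from compound 1 to compound 3 (1.00 log units; beyond the scatter) (the larger of the two steps), so the sulfur group also matters. (Nothing measured here explains either step).

Still open, on these data alone, is how an amine or a carboxylic acid in place of the chlorine of 4-chlorophenyl would behave. Whether a longer chain on the sulfur would move the number further is also unknown.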